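The source may hold more compounds than are shown below. What is called first, only, known or untested is meant among the compounds shown, and "the series" means these compounds.

Compound 3 `COc1ccc(/C=C\C(=O)O)c(OCc2cn(-c3ccc(CO)cc3)nn2)c1CC=C(C)C` in a functional assay on HCT-116 cells (Homo sapiens) for cytotoxicity, read by MTT assay, with a stated time of 24 h (on this read-out lower numbers stand for stronger inhibition and higher numbers for weaker inhibition), gives 31700 nM, the highest of the two numbers in hand; the nearest is compound 1 `COc1ccc(/C=C\C(=O)O)c(OCc2cn(-c3ccccc3I)nn2)c1CC=C(C)C`, which in this assay gives 23100 nM, and the step of a 1.4-fold higher number from compound 1 to compound 3 (0.14 log units; within the scatter) stays within the scatter. For compound 2 `COc1ccc(/C=C\C(=O)O)c(OCc2cn(-c3ccc(NC(C)=O)cc3)nn2)c1CC=C(C)C` the result in this assay is "not determined" (no result reported). Compound 4 `COc1cccc(-n2cc(COc3c(/C=C\C(=O)O)ccc(OC)c3CC=C(C)C)nn2)c1` differs from compound 3 by 3-methoxyphenyl in place of 4-(hydroxymethyl)phenyl on an aromatic nitrogen. Among the measured compounds shown here, the only measured step that touches this same aromatic nitrogen is a 1.4-fold higher number from compound 1 to compound 3 (0.14 log units; within the scatter), where exchanging the group there moved the number only within the scatter, so no step beyond the scatter is expected in this assay here either. For compound 4 the expected step is a 1.1-fold lower number from compound 3 to compound 4 (0.05 log units; within the scatter). Compound 4 is estimated at 28000 nM, within 12000 nM to 65000 nM.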

Compound 4, half-maximal inhibitory concentration: 21600 nM
Compound 4: the middle estimate sits 1.3-fold (0.11 log units) above what was measured; the measured number falls inside the stated range.
By their numbers in this assay, from the lowest: compounds 4, 1 and 3 (each within the scatter of the next).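

In this assay, 3-methoxyphenyl on this aromatic nitrogen gives two steps (a 1.5-fold lower number from compound 3 to compound 4 (0.17 log units; within the scatter) and a 1.1-fold lower number from compound 1 to compound 4 (0.03 log units; within the scatter)), so a third aryl group also leaves the number within the scatter. The exchange from compound 3 to compound 4 goes from 1 hydrogen-bond donor to 0 hydrogen-bond donors with the same heavy atoms, and this too moves the number only within the scatter. No evidence on why this position tolerates these exchanges is available.

Going by these compounds, whether an amine or a carboxylic acid on this phenyl ring would give a step beyond the scatter remains open. So does a longer alkyl chain in place of the aryl group.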